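A swap on a compound stuck at the limit

The source may report more compounds than this note shows. Statements on the series, on what has been measured and on what is new or still open speak of the compounds shown alone.

Measured in a functional assay on MDA-MB-436 cells (Homo sapiens) for antiproliferative activity, read by MTT assay, with a stated time of 24 h; on this read-out higher numbers stand for weaker inhibition and lower numbers for stronger inhibition:
Compound 1 `CC(C)(C)c1ccc(C(CC(=O)O)NC(=O)c2ccc(F)cc2)cc1`: > 100000 nM
Compound 2 `COc1ccc(C(=O)NC(CC(=O)O)c2ccc(C(C)(C)C)cc2)cc1`: > 100000 nM

Neither entry is a true number. In this assay compound 2 gives > 100000 nM, which is a limit of the assay. Compound 1 gives > 100000 nM, which is also a limit. So compound 2 has no exact place on the scale, and the only other result is a limit too.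

Compound 3 `CC(C)(C)c1ccc(C(CC(=O)O)NC(=O)c2ccc(C(F)(F)F)cc2)cc1` shares its core with compound 2 but carries trifluoromethyl in place of methoxy on an aromatic carbon, para to a large group: trifluoromethyl in place of methoxy on an aromatic carbon.

Among the measured compounds shown here, one measured step bears on this change, at the group that changes here: a step that the two limits leave unreadable from compound 1 to compound 2. It replaced fluoro with methoxy, and its size cannot be read. Both results sit together, as the limit of > 100000 nM in this assay, at which 2 of the 2 values shown sit, shows, so neither group has yet given a measurable value. No real gain in this assay is therefore expected for compound 3, and another limit is the likeliest report.

The expected change is a step that the limit leaves unreadable from compound 2 to compound 3. For compound 3 the estimated value is 130000 nM, with an expected range of 50000 nM to 300000 nM.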

Compound 3, half-maximal inhibitory concentration: 82300 nM
Compound 3: the middle estimate sits 1.6-fold (0.20 log units) above what was measured, and the stated range covers the measured number.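

Compound 3 is the first of these compounds to give a true number rather than a limit in this assay, so trifluoromethyl is the only one of the three groups shown on this aromatic carbon, para to a large group, that has an exact place on the scale. The other end of each comparison is a limit. The steps to compound 3 are only floors, one for the change from methoxy (an at least 1.2-fold lower number from compound 2 to compound 3 (0.08 log units; that floor lies within the scatter)) and one for the change from fluoro (an at least 1.2-fold lower number from compound 1 to compound 3 (0.08 log units; that floor lies within the scatter)). Both floors lie within the usual scatter, so a real gain from trifluoromethyl is not established, and the true size of each step stays unknown, with most of the set still stuck at the limit: the limit of > 100000 nM in this assay, at which 2 of the 3 values shown sit.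

Fluoro, methoxy and trifluoromethyl are the only groups shown at this place, so these results cannot tell whether any group there could bring the number well away from the limit. Whether a nitrile or an amine on the same aromatic carbon would give a clearly readable step remains an open question.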